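A few compounds are considered here, and "the series" means these few. Any claim that something is new, unique, unknown or untested is made for them only; others in the source may bear on it.

Working notes on the series. In a functional assay on MCF7 cells (Homo sapiens) (on this read-out higher numbers stand for weaker inhibition of growth and lower numbers for stronger inhibition of growth), compound 1 (`O=S(=O)(/C=C/c1ccc(Cl)cc1Cl)Cc1ccc(Nc2ncnc3ccccc23)cc1`) gives 4000 nM and compound 2 (`O=S(=O)(/C=C/c1ccc(F)cc1Cl)Cc1ccc(Nc2ncnc3ccccc23)cc1`) gives 21000 nM. Compound 2 thus holds the higher of the two numbers, meaning the weaker inhibition of growth of the pair, and the gap lies beyond the scatter.

The next structure is compound 3 (`O=S(=O)(/C=C/c1ccc(C(F)(F)F)cc1F)Cc1ccc(Nc2ncnc3ccccc23)cc1`), and the change is 2-fluoro-4-(trifluoromethyl)phenyl in place of 2-chloro-4-fluorophenyl on a double-bonded chain carbon bound to a double-bonded chain carbon. Within the data shown here, the group that enters carries no chloro, and it brings a trifluoromethyl that no measured compound has.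

Among the measured compounds shown here, only one measured step bears on this, and only in part: a 5.3-fold higher number from compound 1 to compound 2 (0.72 log units; beyond the scatter). This modest step put fluoro in place of chloro on an aromatic carbon of the same aryl group, and the number rose. It says nothing direct about trifluoromethyl, so the data give only weak guidance on direction.

In this assay a small move is expected, a 1.5-fold lower number from compound 2 to compound 3 (0.18 log units; within the scatter), and no shift clearly beyond the scatter is anticipated. Compound 3 is estimated at 14000 nM, with an expected range of 4000 nM to 40000 nM.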

Compound 3, concentration for 50% growth inhibition: 100000 nM
Beside the measured number, compound 3's estimate is 7.1-fold (0.85 log units) below it; the measured number lies above the stated range.
By their numbers in this assay, from the lowest: compound 1; then compound 2; then compound 3.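

In this assay, among these compounds, the aryl group on the double-bonded chain carbon proves less tolerant of change than the single earlier step could show: 2-fluoro-4-(trifluoromethyl)phenyl in place of 2-chloro-4-fluorophenyl gives a 4.8-fold higher number from compound 2 to compound 3 (0.68 log units; beyond the scatter) and the number rises again, now with no chloro left in the group. Set against 2,4-dichlorophenyl, the same group gives a 25-fold higher number from compound 1 to compound 3 (1.40 log units; beyond the scatter) and this is the widest gap in the series, so the three compounds now form an order with 2,4-dichlorophenyl at the low end and every step between them beyond the scatter. No supporting measurement bears on this rise, and its origin stays unassigned.

The compounds shown cannot separate the loss of chloro from the arrival of trifluoromethyl, since both occur within the one change from compound 2 to compound 3. They also leave open whether a methoxy, a nitrile or an amine in this aryl group would hold the number near that of compound 1 or move it lower, and whether the same order would persist on a core other than the shared one.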